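Swapping the anilino aryl: from methyl to chlorine

A few compounds are considered here, and "the series" means these few. Any claim that something is new, unique, unknown or untested is made for them only; others in the source may bear on it.

Measured so far:
compound 1 `N#Cc1c(Nc2ccccc2Cl)nc(SCc2cn(Cc3ccccc3Cl)nn2)nc1-c1ccccc1` — 4640 nM
compound 2 `Cc1ccc(Cn2cc(CSc3nc(Nc4ccc(C)cc4)c(C#N)c(-c4ccccc4)n3)nn2)cc1` — > 64000 nM

The measure throughout is a functional assay on MGC-803 cells (Homo sapiens) for inhibition, read by MTT assay, with a stated time of 72 h; a lower number here means a stronger inhibitor, a higher number a weaker inhibitor. In this assay compound 1 gives 4640 nM. Compound 2 reaches only a limit of this assay, > 64000 nM, so no number is known for it, only that it sits at the limit of > 64000 nM in this assay, at which 1 of the 2 values shown sits. Compound 3 `Cc1ccc(Cn2cc(CSc3nc(Nc4ccccc4Cl)c(C#N)c(-c4ccccc4)n3)nn2)cc1` has not yet been measured. It differs from compound 2 in one place: 2-chlorophenyl in place of 4-methylphenyl on a nitrogen on an aromatic ring. Compound 3 thus carries on that nitrogen the same 2-chlorophenyl group that compound 1 carries, while keeping the rest of compound 2. Among the compounds with values here, no measured pair shows this exact change, so its size must be guessed. Because compound 1, which bears the 2-chlorophenyl group, gives 4640 nM, the step away from the 4-methylphenyl group of compound 2 is expected to move toward stronger inhibition. The expected step is an at least 4.2-fold lower number from compound 2 to compound 3 (0.63 log units; beyond the scatter). Compound 3 is therefore estimated at 15000 nM, with a range from 4000 nM to 64000 nM.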

Compound 3, half-maximal inhibitory concentration: 17300 nM
The estimate for compound 3 lay 1.2-fold (0.06 log units) below the measured number; measured number inside the range.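

In this assay, the swap on the nitrogen on an aromatic ring now has a measured effect: 2-chlorophenyl in place of 4-methylphenyl gives an at least 3.6-fold lower number from compound 2 to compound 3 (0.56 log units; beyond the scatter). This step gives only a minimum size, since compound 2 reaches a limit and has no exact number: the limit of > 64000 nM in this assay, at which 1 of the 3 values shown sits. The 2-chlorophenyl group on that nitrogen does not by itself account for the activity of compound 1, since 4-methylphenyl in place of 2-chlorophenyl on a saturated chain carbon bound to an aromatic nitrogen gives a 3.7-fold higher number from compound 1 to compound 3 (0.57 log units; beyond the scatter), which shows that this second place also affects the result.

The swap on the nitrogen changes both the substituent and its place on the ring, so the compounds shown cannot separate the contribution of the chlorine from that of its position. Also open, as far as these compounds go, is how this nitrogen would respond to a different group, such as an unsubstituted phenyl, a pyridine ring or a simple alkyl chain, and whether the changes at the two places would add up in the same way on other compounds.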